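The source may hold more compounds than are shown below. What is called first, only, known or untested is meant among the compounds shown, and "the series" means these compounds.

Measured compounds:
compound 1 `Cn1nc2c(=O)n(CC3(O)CCN(Cc4ccc(-c5ccco5)cc4Cl)CC3)cnc2c1-c1ccc(CO)cc1` — 42.5 nM
compound 2 `Cn1nc2c(=O)n(CC3(O)CCN(Cc4ccc(-c5ccoc5)cc4Cl)CC3)cnc2c1-c1ccc(CN)cc1` — 177 nM
compound 3 `Cn1nc2c(=O)n(CC3(O)CCN(Cc4ccc(-c5ccsc5Cl)cc4Cl)CC3)cnc2c1-c1ccc(CN)cc1` — 453 nM

In an assay on isolated protein for inhibition of ubiquitin carboxyl-terminal hydrolase 7 (Homo sapiens), with stated times of 30 min and 2 h (a lower number here means a stronger inhibitor, a higher number a weaker inhibitor), compound 1 gives 42.5 nM, the lowest number of the three; compound 2 stands next with 177 nM, and compound 3, with 453 nM, furthest. Among the compounds with values here, compound 1 and compound 2 differ in two places at once, so their values are compared as a pair only, with no single step assigned. Within the data shown here, the one clean step recorded, a 2.6-fold higher number from compound 2 to compound 3 (0.41 log units; beyond the scatter), sits on a different part of the molecule and does not inform the change at hand.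

Compound 4 `Cn1nc2c(=O)n(CC3(O)CCN(Cc4ccc(-c5ccco5)cc4Cl)CC3)cnc2c1-c1ccc(CNC(=O)C(F)(F)F)cc1` departs from compound 1 by ((trifluoromethyl)carbonyl)amino in place of hydroxy on a saturated chain carbon bound to an aromatic carbon. Among the measured compounds shown here, no measured pair isolates this exchange: the only replacement at this position, in compound 2, is tied to a second change elsewhere. The expectation therefore rests on compound 1 alone, and a step in this assay is expected that is small, if any, leaning toward a higher number, estimated as a 1.9-fold higher number from compound 1 to compound 4 (0.27 log units; within the scatter). Compound 4 is expected to give about 80 nM, within 25 nM to 300 nM.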

Compound 4, half-maximal inhibitory concentration: 2060 nM
The estimate for compound 4 lay 26-fold (1.41 log units) below the measured number; the measured number lies above the stated range.
By their numbers in this assay, from the lowest: compound 1; then compound 2; then compound 3; then compound 4.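

In this assay, within the data shown here, the saturated chain carbon bound to an aromatic carbon is a sensitive place: ((trifluoromethyl)carbonyl)amino in place of hydroxy gives a 48-fold higher number from compound 1 to compound 4 (1.69 log units; beyond the scatter), the only clean reading of a change at this position. Hydroxy and ((trifluoromethyl)carbonyl)amino carry the same counts of hydrogen-bond donors and acceptors and no net charge, so those counts do not track this step. No measurement shown here bears on the reason for the step.

Going by these compounds, whether the step belongs to the trifluoromethyl end or to the carbonylamino link stays open, and acetylamino at the same place would help separate the two. Amino at this place appears only in compound 2, tied to a second change elsewhere, so its own contribution cannot be read.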